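Benzamide series: amide side-chain variation at the serotonin-4 receptor

The source may hold more compounds than are shown below. What is called first, only, known or untested is meant among the compounds shown, and "the series" means these compounds.

Measured so far:
compound 1 `COc1cc(N)c(Cl)cc1C(=O)NCC1CCNCC1` — 316 nM
compound 2 `COc1cc(N)c(Cl)cc1C(=O)NC1CCNCC1` — 1580 nM

Both measured compounds share the same aromatic core and differ only in the amine-bearing substituent on the amide nitrogen. In an assay on HEK293 cells for displacement of a labelled ligand from 5-hydroxytryptamine receptor 4 (Homo sapiens), read by scintillation counting (a higher number here means a weaker inhibitor, a lower number a stronger inhibitor), compound 1 gives 316 nM, the lower of the two numbers. In this assay compound 2 gives 1580 nM, a higher number that lies beyond the usual scatter, so compound 1 stands as the more potent of the pair on the numbers to hand.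

The next compound, compound 3 `COc1cc(N)c(Cl)cc1C(=O)NCCN1CCNCC1`, is to be measured in this assay. It is related to compound 1 by (piperazin-1-yl)methyl in place of piperidin-4-yl on a saturated chain carbon bound to an amide-type nitrogen. For the measured compounds named here, no measured step of this kind exists, so the direction can only be guessed from the structural change. The expectation is a modest loss of potency, with the step from compound 1 to compound 3 estimated as a 1.9-fold higher number from compound 1 to compound 3 (0.28 log units; within the scatter), though a result within the scatter would not be surprising.

For compound 3 the estimated inhibition constant in this assay is 600 nM, expected to lie between 150 nM and 2500 nM.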

Compound 3, inhibition constant: 1260 nM
Beside the measured number, compound 3's estimate is 2.1-fold (0.32 log units) below it; measured number inside the range.
By their numbers in this assay, from the lowest: compound 1; then compounds 3 and 2 (each within the scatter of the next).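

In this assay, for the compounds shown here, (piperazin-1-yl)methyl in place of piperidin-4-yl on a saturated chain carbon bound to an amide-type nitrogen gives a 4.0-fold higher number from compound 1 to compound 3 (0.60 log units; beyond the scatter), the first measured step at this position, and it shows that compound 1 is not matched by this larger ring-bearing group. The change swaps one six-membered non-aromatic ring with 1 hetero atom for one with 2 hetero atoms and also adds a methyl link, so this single step cannot be divided between those two differences. No measurement in hand bears on the reason for the step.

From the compounds shown here alone, it remains open whether the higher number of compound 3 follows from the second ring nitrogen, from the attachment of the ring through nitrogen, or from the added chain carbon. A (piperidin-1-yl)methyl group or a (morpholin-4-yl)methyl group at the same place, together with a 2-(piperidin-4-yl)ethyl chain, would separate these differences and show how far the position tolerates change in the ring and in the link.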